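A few compounds are considered here, and "the series" means these few. Any claim that something is new, unique, unknown or untested is made for them only; others in the source may bear on it.

Compound 1 `Cn1ccc2cc(-c3cc4nccc(-c5ccc(F)cc5)n4n3)ccc21`, compound 2 `COc1cc(-c2ccnc3c(-c4ccc(C)cc4)cnn23)cc(OC)c1OC` and compound 3 `COc1cc(-c2ccnc3cc(-c4ccc(C(C)=O)cc4)nn23)cc(OC)c1OC` share a core and were tested in a functional assay on HeLa cells (Homo sapiens) for inhibition, read by CCK-8 assay, with a stated time of 48 h; a lower number here means a stronger inhibitor, a higher number a weaker inhibitor. Compound 1 gives 5210 nM. For compound 2 the assay reports only > 10000 nM, which is a limit of the assay and not a number. Compound 2 therefore stands at the limit of > 10000 nM in this assay, at which 1 of the 3 values shown sits. Compound 3 gives 1810 nM, the lowest of the two numbers obtained, and the gap between compound 3 and compound 1 lies beyond the usual scatter of repeated measurements.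

Compound 4 `COc1cc(-c2ccnc3cc(-c4ccccc4)nn23)cc(OC)c1OC` has not yet been measured. It differs from compound 3 in one place: hydrogen in place of acetyl on an aromatic carbon. For the measured compounds named here, no pair of measured compounds differs in a single place, so the data give no step from which the effect of this change can be read. Compound 4 is expected to give about 3500 nM in this assay, with a likely range from 1200 nM to 10000 nM. The expected step of a 1.9-fold higher number from compound 3 to compound 4 (0.29 log units; within the scatter) is a modest weakening, close to the edge of the scatter.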

Compound 4, half-maximal inhibitory concentration: 458 nM
For compound 4 the middle estimate is 7.6-fold (0.88 log units) above the measured one, and the stated range ends above it.
By their numbers in this assay, from the lowest: compound 4; then compound 3; then compound 1. At a limit, above all of these: compound 2.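

Replacing acetyl with hydrogen on this aromatic carbon, para to a large group, gives a 4.0-fold lower number from compound 3 to compound 4 (0.60 log units; beyond the scatter) in this assay. For the compounds shown here, this is the first change in the set that can be read in a single place, and it shows that the acetyl, with its carbonyl, is not required at this position for activity in these cells: the plain phenyl gives the lower number of the two. Nothing in the data shown explains why the number falls with this change.

A single step cannot show whether the gain belongs to the loss of acetyl in particular or would come with the removal of other groups from this carbon. As far as these compounds go, whether an amine or a carboxylic acid at the same place would match hydrogen, or fall back towards acetyl, remains open.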